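The compounds below may be only part of what the source reports. "The series", "measured", "known", "first", "only" and "open" are said of these compounds alone.

Measured in a functional assay on the whole organism with Mus musculus as the target; a higher number here means that more compound is needed for the effect, a lower number that less compound is needed:
- compound 1 `NC(=O)/C=C/c1cccc(C(F)(F)F)c1`: 54.5 mg/kg
- compound 2 `CNC(=O)/C=C(\C)c1cccc(C(F)(F)F)c1`: > 100 mg/kg
- compound 3 `CN1C(=O)CCC1(O)c1cccc(C(F)(F)F)c1`: 133 mg/kg

The entry for compound 2 at > 100 mg/kg is a limit, not a number. Of the two true numbers, compound 3 at 133 mg/kg is the higher, and its gap to compound 1 lies beyond the scatter.

Compound 4 `CCCN1C(=O)CCC1(O)c1cccc(C(F)(F)F)c1` has ethyl in place of hydrogen on a saturated chain carbon bound to an amide-type nitrogen in a ring. Within the data shown here, no measured step in this assay covers this change, so from compound 3 at 133 mg/kg the shift is not expected to leave the scatter. The expected change is a 1.1-fold lower number from compound 3 to compound 4 (0.04 log units; within the scatter). For compound 4 the estimated value is 120 mg/kg, with an expected range of 55 mg/kg to 260 mg/kg.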

Compound 4, dose for half-maximal effect: 200 mg/kg
For compound 4 the middle estimate is 1.7-fold (0.22 log units) below the measured one; measured number inside the range.
By their numbers in this assay, from the lowest: compound 1; then compounds 3 and 4 (each within the scatter of the next).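

In this assay, among these compounds, the step of a 1.5-fold higher number from compound 3 to compound 4 (0.18 log units; within the scatter) is the first reading at this position: ethyl in place of hydrogen on a saturated chain carbon bound to an amide-type nitrogen in a ring, the same difference as methyl to propyl. Compound 3 and compound 4 stand within the scatter of each other, so this added chain length leaves the number where it was. No measured property shown here bears on this change.

One step sets no trend at this position. From the compounds shown here alone, whether a longer chain, or a propyl chain ending in an amine or a carboxylic acid, also stays within the scatter remains open.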